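Configuration at the ring stereocentre: compound 2 to compound 3

The source may hold more compounds than are shown below. What is called first, only, known or untested is meant among the compounds shown, and "the series" means these compounds.

Measured in a functional assay on the whole organism with Mus musculus as the target; a lower number here means that less compound is needed, a higher number that more compound is needed for the effect:
- compound 1 `C[C@H]1CCC(=O)N1CC#CCN(C)C`: 50 umol/kg
- compound 2 `C[C@@H]1CCC(=O)N1CC#CCN(C)C`: 2.4 umol/kg

Not yet measured:
- compound 3 `CC1CCC(=O)N1CC#CCN(C)C`

Compound 2, at 2.4 umol/kg, holds the lower of the two numbers in this assay, so less of it is needed for the effect. The next step is the two compounds have the same atoms and bonds; at least one stereo element is drawn with a configuration in one of them and without one in the other: 1 of 1 stereo elements differ; a stereocentre at a saturated ring carbon is drawn R in compound 2 and without a configuration in compound 3. No group leaves or enters, so the question is only what the loss of a defined configuration does to the number.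

Among the compounds with values here, the one measured step, a 21-fold lower number from compound 1 to compound 2 (1.32 log units; beyond the scatter), bears directly on this, and it goes with the fact that compounds 1 and 2 differ only in the configuration as drawn. If compound 3 is a mixture of the two configurations, it would contain the form of compound 2, at 2.4 umol/kg, diluted by the form of compound 1, at 50 umol/kg. A higher number than that of compound 2 is therefore expected, though far closer to compound 2 than to compound 1. This rests on the assumption about the mixture, which the structure as drawn does not confirm.

The estimated size of the change is a 1.9-fold higher number from compound 2 to compound 3 (0.28 log units; within the scatter). For compound 3 the expected value is 4.6 umol/kg, with an estimated range of 2.4 umol/kg to 11 umol/kg.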

Compound 3, dose for half-maximal effect: 5.5 umol/kg
Compound 3: middle estimate off by 1.2-fold (0.08 log units), on the low side, within the range that was stated.
By their numbers in this assay, from the lowest: compound 2; then compound 3; then compound 1.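

In this assay, removing the defined configuration at the saturated ring carbon changes the number far less when starting from the R form, a 2.3-fold higher number from compound 2 to compound 3 (0.36 log units; beyond the scatter), than when starting from the S form, a 9.1-fold lower number from compound 1 to compound 3 (0.96 log units; beyond the scatter). Compound 3 therefore falls between the two defined forms and nearer to compound 2, which fits a sample in which the R form sets the number, although the drawing does not state its composition. Even this smaller step lies beyond the scatter, so a defined R configuration at this stereocentre gives a readable advantage over the undefined drawing, and the comparison isolates that single feature: the fact that one of compounds 2 and 3 is drawn with a defined configuration and the other without, at the place where they differ

How much of each form compound 3 contains stays open, so the compounds shown cannot say whether its number is what a given mixture of compound 1 and compound 2 would produce. Also open, from the compounds shown here alone, is whether the preference for the R form persists with an ethyl group at the stereocentre, or with a cyclic amine in place of the dimethylamine.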